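The source may hold more compounds than are shown below. What is called first, only, known or untested is meant among the compounds shown, and "the series" means these compounds.

Working notes on the series, in an ADME assay on NHDF cells (Homo sapiens) for cytotoxicity, read by MTT assay, with a stated time of 72 h; a lower number here means a stronger inhibitor, a higher number a weaker inhibitor. Compound 1 `COc1ccc(/C=C2\CCC/C(=C\c3ccc(Cl)cc3)C2=O)cc1OC` reads 11200 nM. Compound 2 `COc1ccc(/C=C2\CCC/C(=C\c3cccc(Cl)c3Cl)C2=O)cc1OC` reads 18500 nM, and the step between them, a 1.7-fold higher number from compound 1 to compound 2 (0.22 log units; within the scatter), gives no separation. Compound 3 `COc1ccc(/C=C2\CCC/C(=C\c3ccc(Cl)cc3Cl)C2=O)cc1OC` gives only a limit, > 50000 nM, and not a number. It stands apart from the other two measured compounds, with an at least 4.4-fold higher number from compound 1 to compound 3 (0.64 log units; beyond the scatter) and an at least 2.7-fold higher number from compound 2 to compound 3 (0.43 log units; beyond the scatter), and both of these sizes are themselves bounds.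

The next change leads to compound 4 `COc1ccc(/C=C2\CCC/C(=C\c3ccc(O)c(Cl)c3)C2=O)cc1OC`: 3-chloro-4-hydroxyphenyl in place of 2,4-dichlorophenyl on a double-bonded chain carbon bound to a double-bonded ring carbon, (3-chloro-4-hydroxyphenyl in place of 2,4-dichlorophenyl on a double-bonded chain carbon bound to a double-bonded ring carbon). Among the measured compounds shown here, no measured step introduces this hydroxy-bearing group, so the expectation is only a loose one. For the measured compounds named here, of the three measured compounds, only the one carrying 2,4-dichlorophenyl gave a limit. With that group gone, compound 4 is expected to read close to compound 1 at 11200 nM and compound 2 at 18500 nM. The estimated step is an at least 3.3-fold lower number from compound 3 to compound 4 (0.52 log units; beyond the scatter), towards a lower number. For compound 4 the estimate is 15000 nM, with an expected range of 4500 nM to 45000 nM.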

Compound 4, half-maximal inhibitory concentration: 21900 nM
Compound 4: the middle estimate sits 1.5-fold (0.16 log units) below what was measured, within the range that was stated.
By their numbers in this assay, from the lowest: compounds 1, 2 and 4 (each within the scatter of the next). At a limit, above all of these: compound 3.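

In this assay, 3-chloro-4-hydroxyphenyl on a double-bonded chain carbon bound to a double-bonded ring carbon gives a measurable reading where 2,4-dichlorophenyl did not, with an at least 2.2-fold lower number from compound 3 to compound 4 (0.35 log units; beyond the scatter), and this size is itself a bound. The same group gives no separation from the other two groups at this place, with a 1.2-fold higher number from compound 2 to compound 4 (0.07 log units; within the scatter) and a 2.0-fold higher number from compound 1 to compound 4 (0.29 log units; within the scatter), so a hydroxy-bearing group here reads with 4-chlorophenyl and 2,3-dichlorophenyl. Compound 3 is now the only one of the four compounds held at a limit and not a number: the limit of > 50000 nM in this assay, at which 1 of the 4 values shown sits.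

Among the compounds shown here, with only one hydroxy-bearing compound, the series does not show whether the hydroxy or the chloro of this group matters for the reading. On these data alone, how an amine or a carboxylic acid at this place would read also stays open.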